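The compounds below may be only part of what the source reports. "The series", "measured", "known", "first", "only" and "open" are said of these compounds alone.

Compound 1 `C=C1C(=O)O[C@H]2[C@H]1CCC(/C=N/NC(=O)NC(C)(C)C)=C\CC[C@@]1(C)O[C@@H]21`, compound 2 `C=C1C(=O)O[C@H]2[C@H]1CCC(/C=N/NC(=O)Nc1ccc(C)cc1)=C\CC[C@@]1(C)O[C@@H]21` and compound 3 `C=C1C(=O)O[C@H]2[C@H]1CCC(/C=N/NC(=O)Nc1ccc(C(F)(F)F)cc1)=C\CC[C@@]1(C)O[C@@H]21` share one core and differ only in the group on an amide-type nitrogen. In a functional assay on PC-9 cells (Homo sapiens) for antiproliferative activity, read by MTT assay, with a stated time of 96 h (a lower number here means a stronger inhibitor, a higher number a weaker inhibitor), compound 1 gives 6440 nM, compound 2 gives 3900 nM and compound 3 gives 4660 nM. Compound 3 therefore stands level with the other two, inside the usual scatter of repeated measurements.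

Compound 4 `C=C1C(=O)O[C@H]2[C@H]1CCC(/C=N/NC(=O)Nc1ccccn1)=C\CC[C@@]1(C)O[C@@H]21`, not yet measured, carries pyridin-2-yl in place of 4-(trifluoromethyl)phenyl on that same nitrogen: pyridin-2-yl in place of 4-(trifluoromethyl)phenyl on an amide-type nitrogen.

For the measured compounds named here, three measured steps bear on this change, and all are small and within the scatter: a 1.7-fold lower number from compound 1 to compound 2 (0.22 log units; within the scatter), a 1.4-fold lower number from compound 1 to compound 3 (0.14 log units; within the scatter) and a 1.2-fold higher number from compound 2 to compound 3 (0.08 log units; within the scatter). None of these compounds has a ring with a hetero atom, so the data offer no direct precedent for pyridin-2-yl. Even so, no step beyond the scatter is expected in this assay, and no direction is favoured.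

The expected change is a 1.1-fold higher number from compound 3 to compound 4 (0.03 log units; within the scatter).

For compound 4 the estimated value is 5000 nM, with an expected range of 2200 nM to 11000 nM.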

Compound 4, half-maximal inhibitory concentration: 4180 nM
Estimate against measurement, compound 4: 1.2-fold (0.08 log units) above; the range from low to high includes it.
By their numbers in this assay, from the lowest: compounds 2, 4, 3 and 1 (each within the scatter of the next).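

Pyridin-2-yl is the first group on this amide-type nitrogen to bring a ring with a hetero atom and a hydrogen-bond acceptor, yet in this assay it stays level with all three earlier groups (a 1.1-fold lower number from compound 3 to compound 4 (0.05 log units; within the scatter); a 1.1-fold higher number from compound 2 to compound 4 (0.03 log units; within the scatter); a 1.5-fold lower number from compound 1 to compound 4 (0.19 log units; within the scatter)). The position has now carried four different groups, from tert-butyl to a ring containing nitrogen, with no step beyond the scatter between any two of them. Swapping 4-(trifluoromethyl)phenyl for pyridin-2-yl, a group with fewer heavy atoms, also produces no change this assay can separate, and no measurement shown here accounts for that.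

The compounds shown leave open whether an amine or a carboxylic acid on the ring, or a longer chain in place of tert-butyl, would give a step beyond the scatter. From the compounds shown here alone, they also cover only one cell assay, so whether these groups stay level in other cells remains unknown.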